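This account rests on a few compounds, and the source may have more. Where it says the series, first, only, none or still open, it means among the compounds named here.

Measured so far:
- compound 1 `Oc1ccc(CNC2(c3ccccc3F)CCCC2)cc1CN1CCN(c2ccccc2)CC1`: > 100000 nM (a limit)
- compound 2 `CCN(CC)Cc1cc(CNC2(c3ccccc3F)CCCC2)ccc1O`: "not determined" (no result reported)

In an ADME assay on HMEC cells (Homo sapiens) for cytotoxicity, with a stated time of 72 h (a higher number here means a weaker inhibitor, a lower number a stronger inhibitor), compound 2 has no number, and its entry reads "not determined" (no result reported). The only other entry, for compound 1, is also no number but a limit of this assay. The next analogue is compound 3 `Oc1ccc(CNC2(c3ccccc3F)CCCC2)cc1CN1CCCCC1`. The change is piperidin-1-yl in place of diethylamino on a saturated chain carbon bound to an aromatic carbon. Among the measured compounds shown here, no measured step exists, and a step from this swap in this assay is expected to stay within the scatter. For compound 3 the expected value is 60000 nM, with an estimated range of 20000 nM to 150000 nM.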

Compound 3, half-maximal inhibitory concentration: > 100000 nM
Compound 3: a limit, no number; the forecaster's own chance of this, stated with the estimate: 45%; middle value at least 1.6-fold (0.22 log units) away from the limit.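

No step can be read between compound 2 and compound 3 in this assay. Compound 3 gives > 100000 nM, which is a limit and not a number. What the swap of diethylamino for piperidin-1-yl does to the half-maximal inhibitory concentration stays open: the limit of > 100000 nM in this assay, at which 2 of the 3 values shown sit.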